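A Biphenyl Amide on a Weakly Inhibiting Phosphatase Scaffold

The compounds below may be only part of what the source reports. "The series", "measured", "known", "first", "only" and "open" are said of these compounds alone.

Of the compounds shown here, three have been measured in an assay on isolated protein for inhibition of tyrosine-protein phosphatase non-receptor type 13 (Homo sapiens), read by spectrophotometry; on this read-out higher numbers stand for weaker inhibition and lower numbers for stronger inhibition. Compound 1 `Cc1ccc(O)c(C(O)(C(F)(F)F)C(F)(F)F)c1` gives 454000 nM. Compound 2 `Oc1cc(-c2ccccc2)ccc1C(O)(C(F)(F)F)C(F)(F)F` reaches only the limit of > 500000 nM, so no number is known for it. Compound 3 `COc1ccc(CNC(=O)COc2ccc3cc(C(O)(C(F)(F)F)C(F)(F)F)c(O)cc3c2)cc1OC` likewise gives only the limit > 20000 nM; it is therefore not placed by a number, and it stands as one of two limits among the three values. Compound 4 `O=C(COc1ccc2cc(C(O)(C(F)(F)F)C(F)(F)F)c(O)cc2c1)Nc1ccc(-c2ccccc2)cc1` differs from compound 3 in one place: 4-phenylphenyl in place of 3,4-dimethoxybenzyl on an amide-type nitrogen. Within the data shown here, no measured pair shows what such a change does here, so no step beyond the usual scatter is expected in either direction. The step that the limit leaves unreadable from compound 3 to compound 4 is an estimate only. Compound 4 is expected to give about 30000 nM in this assay, within 8000 nM to 200000 nM, most likely reported again as a limit.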

Compound 4, half-maximal inhibitory concentration: 2800 nM
The estimate for compound 4 lay 11-fold (1.03 log units) above the measured number; the whole stated range lies above it.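

The group on the amide-type nitrogen clearly matters: 4-phenylphenyl in place of 3,4-dimethoxybenzyl gives an at least 7.1-fold lower number from compound 3 to compound 4 (0.85 log units; beyond the scatter). The earlier compounds shown here offered no pair that could show this position affecting inhibition. The full size of the step cannot be read because compound 3 stands at a limit: the limit of > 20000 nM in this assay, at which 1 of the 4 values shown sits.

The change adds a second aromatic ring and removes both methoxy oxygens at once, so these two differences cannot be separated. On these data alone, it also remains open whether a group carrying a carboxylic acid or an amine on this nitrogen would inhibit as well as 4-phenylphenyl.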